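From a Nitrile to a Cyclopropyl Ring on the Core

A few compounds are considered here, and "the series" means these few. Any claim that something is new, unique, unknown or untested is made for them only; others in the source may bear on it.

Of the compounds shown here, three sharing one core have been tested in an in vitro assay on Sf21 cells for inhibition of high affinity 3',5'-cyclic-AMP phosphodiesterase 7A (Homo sapiens); a lower number here means a stronger inhibitor, a higher number a weaker inhibitor. Compound 1 `CNc1nc(NC)nc(NC2(C#N)CCCCC2)n1` reaches only the assay limit, given as > 1000 nM. Compound 2 `CNc1nc(NC2(C#N)CCCCC2)nc(SC)n1` gives 46 nM in this assay. Compound 3 `CNc1nc(C#N)nc(NC2(C#N)CCCCC2)n1` also reaches only the assay limit, reported as > 1000 nM, which is a limit and not a measured number. Compound 3 therefore stands at the weak end of what has been seen so far, together with the other compound at that same limit (the limit of > 1000 nM in this assay, at which 2 of the 3 values shown sit). The step of an at least 21-fold lower number from compound 1 to compound 2 (1.33 log units; beyond the scatter) is large, and so is the step back an at least 21-fold higher number from compound 2 to compound 3 (1.33 log units; beyond the scatter), whereas the step that the two limits leave unreadable from compound 1 to compound 3 cannot be read between two limits.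

Compound 4 `CNc1nc(NC2(C#N)CCCCC2)nc(C2CC2)n1` arises from compound 3 by the change (cyclopropyl in place of cyano on an aromatic carbon). Among the compounds with values here, two measured steps touch this position: an at least 21-fold higher number from compound 2 to compound 3 (1.33 log units; beyond the scatter) and the unreadable a step that the two limits leave unreadable from compound 1 to compound 3; only the methylsulfanyl group has so far given a low number there. Going by these compounds, the cyclopropyl group is untested, so the expected step is estimated as an at least 3.3-fold lower number from compound 3 to compound 4 (0.52 log units; beyond the scatter). Compound 4 is expected to give about 300 nM, with a range from 40 nM to 3000 nM.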

Compound 4, half-maximal inhibitory concentration: 539 nM
Estimate against measurement, compound 4: 1.8-fold (0.25 log units) below; the range from low to high includes it.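

In this assay, cyclopropyl is the second group at this position, after methylsulfanyl, to give a measured number and not a limit, yet replacing methylsulfanyl with it still gives a 12-fold higher number from compound 2 to compound 4 (1.07 log units; beyond the scatter). Against cyano and methylamino, the change gives only an at least 1.8-fold lower number from compound 3 to compound 4 (0.26 log units; that floor lies within the scatter) and an at least 1.8-fold lower number from compound 1 to compound 4 (0.26 log units; that floor lies within the scatter), so neither step alone establishes a real gain. Both of these readings are floors, set by partner compounds that reach only a limit: the limit of > 1000 nM in this assay, at which 2 of the 4 values shown sit.

The compounds shown leave open whether the low number depends on the sulfur atom or would also appear with a methoxy group, an ethyl group or a chlorine atom at this position. Going by these compounds, whether a longer chain on the sulfur, as in ethylsulfanyl, would keep that low number also remains open.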